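Moving a fluorine on the phenyl group of compound 2

A few compounds are considered here, and "the series" means these few. Any claim that something is new, unique, unknown or untested is made for them only; others in the source may bear on it.

In a functional assay on HeLa cells (Homo sapiens) for antiproliferative activity, read by MTT assay, with a stated time of 48 h (a lower number here means a stronger inhibitor, a higher number a weaker inhibitor), compound 2 (`O=C(/C=C/c1ccccc1)Nc1cc2c(Nc3ccc(F)c(Cl)c3)ncnc2s1`) gives 2140 nM and sits in the middle of the three measured compounds. Compound 1 (`COc1ccc(/C=C/C(=O)Nc2cc3c(Nc4ccc(Cl)c(Cl)c4)ncnc3s2)cc1`) gives the lowest number (33 nM) and compound 3 (`COc1ccc(/C=C/C(=O)Nc2cc3c(Nc4cc(Cl)cc(Cl)c4)ncnc3s2)cc1`) the highest (43300 nM). Compound 4 (`O=C(/C=C/c1ccccc1)Nc1cc2c(Nc3cccc(Cl)c3F)ncnc2s1`) has the same atoms as compound 2, joined differently: 3-chloro-2-fluorophenyl in place of 3-chloro-4-fluorophenyl on a nitrogen on an aromatic ring with 3-chloro-2-fluorophenyl in place of 3-chloro-4-fluorophenyl on a nitrogen on an aromatic ring. Among the compounds with values here, only one measured step bears on this change, and it also rearranges halogens on that phenyl group with the atoms unchanged. That step is large, and it is a 1300-fold higher number from compound 1 to compound 3 (3.12 log units; beyond the scatter) in a single pair with a different halogen set. Going by that one pair, a higher number is expected in this assay but a smaller step, since here the halogen that moves is a fluorine and the evidence is thin. The expected change is a 5.6-fold higher number from compound 2 to compound 4 (0.75 log units; beyond the scatter) as an estimate. For compound 4 the estimated value is 12000 nM with an expected range of 1500 nM to 60000 nM in this reading.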

Compound 4, half-maximal inhibitory concentration: 34900 nM
Estimate against measurement, compound 4: 2.9-fold (0.46 log units) below; the range from low to high includes it.
By their numbers in this assay, from the lowest: compound 1; then compound 2; then compounds 4 and 3 (each within the scatter of the next).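

In this assay, replacing 3-chloro-4-fluorophenyl with 3-chloro-2-fluorophenyl on the nitrogen gives a 16-fold higher number from compound 2 to compound 4 (1.21 log units; beyond the scatter), so rearranging the halogens on this phenyl group matters even when the two groups carry the same chlorine and fluorine. The earlier pair, a 1300-fold higher number from compound 1 to compound 3 (3.12 log units; beyond the scatter), showed that direction only for dichlorophenyl groups on compounds carrying the methoxy group; the new pair shows it for a chlorofluorophenyl group on compounds without that methoxy group, and neither pair goes against it. Nothing given here explains why this rearrangement raises the number.

From the compounds shown here alone, it remains open whether 3-chloro-2-fluorophenyl would give a similar step on the core of compound 1. The compounds shown also leave open how this assay would respond to a nitrile or an amine in place of either halogen on the phenyl group.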